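The compounds below may be only part of what the source reports. "The series", "measured", "known", "first", "only" and "open" are said of these compounds alone.

Three compounds built on a shared core have been examined in a toxicity assay on HepG2 2.2.15 cells (Homo sapiens) for cytotoxicity, read by CellTiter-Glo; a lower number here means that less compound is tolerated, a higher number that more compound is tolerated. Compound 1 `C[C@H]1Cn2ncc(N3CC(c4ccccc4)CC3=O)c2CN1S(=O)(=O)Nc1cc(F)c(F)c(F)c1` reaches only a limit of the assay, > 2000 nM; that reading is a limit, not a number. Compound 2 `O=C1OC(c2ccc(F)cc2)CN1c1cnn2c1CN(C(=O)Nc1cc(F)c(F)c(F)c1)C(C1CC1)C2` gives 3560 nM in this assay. Compound 3 `O=C1CC(c2cnco2)CN1c1cnn2c1CN(C(=O)Nc1cc(F)c(F)c(F)c1)C(C1CC1)C2` gives 139000 nM in this assay, the higher of the two numbers, and its gap to compound 2 lies beyond the usual scatter of such measurements. Of the three readings, one is the limit of > 2000 nM in this assay, at which 1 of the 3 values shown sits.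

Compound 4 `O=C1CC(c2ccccn2)CN1c1cnn2c1CN(C(=O)Nc1cc(F)c(F)c(F)c1)C(C1CC1)C2` differs from compound 3 in one place only: pyridin-2-yl in place of 1,3-oxazol-5-yl on a saturated ring carbon. Among the compounds with values here, no measured pair shows this particular change, so its effect in this assay is not known from the data. The step is expected to be small, a 1.4-fold lower number from compound 3 to compound 4 (0.14 log units; within the scatter), no larger than the scatter and without a clear direction. Compound 4 is therefore estimated at 100000 nM in this assay, with a range from 30000 nM to 250000 nM.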

Compound 4, half-maximal cytotoxic concentration: 96200 nM
Estimate against measurement, compound 4: 1.0-fold (0.02 log units) above, and the stated range covers the measured number.
By their numbers in this assay, from the lowest: compound 2; then compounds 4 and 3 (each within the scatter of the next).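

Replacing 1,3-oxazol-5-yl with pyridin-2-yl gives the first single-place step read at this saturated ring carbon: in this assay there is a 1.4-fold lower number from compound 3 to compound 4 (0.16 log units; within the scatter). At this place, two ring bonds from the ring nitrogen, this read-out therefore does not separate a five-membered aromatic ring with 2 hetero atoms from a six-membered aromatic ring with 1 hetero atom. The data shown bear on no reason for this, and nothing measured here explains the step.

Within the data shown here, this single step covers only two aromatic rings, so it remains open whether the tolerance holds for other kinds of group. A carboxylic acid, an amine or a short alkyl chain on the same carbon might or might not move the number beyond the scatter.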